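The source may report more compounds than this note shows. Statements on the series, on what has been measured and on what is new or still open speak of the compounds shown alone.

Measured so far:
Compound 1 `O=C(CCCCC(S)CCS)Nc1ccc(F)cc1`: 8.11%
Compound 2 `O=C(CCCCC(S)CCS)Nc1ccc([N+](=O)[O-])c(C(F)(F)F)c1`: 1.95%

In a functional assay on HO8910 cells (Homo sapiens) for inhibition, read by MTT assay, with a stated time of 24 h, tested at 0.1 ug/mL (a higher number here means more inhibition of growth at the concentration tested, a lower number less inhibition of growth), compound 2 gives 1.95%, and this lies within the usual scatter of compound 1 at 8.11%, so the two cannot be told apart. Compound 3 `O=C(CCCCC(S)CCS)Nc1ccc([N+](=O)[O-])cc1` carries hydrogen in place of trifluoromethyl on an aromatic carbon of compound 2 (hydrogen in place of trifluoromethyl on an aromatic carbon). Among the compounds with values here, no two measured compounds differ in one place only, so the data offer no direct guide to this swap. Nothing beyond the scatter is expected, and the estimated a number 3.1 percentage points higher from compound 2 to compound 3 (within the scatter) is small. For compound 3 the expected value is 5%, with an estimated range of 0% to 13%.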

Compound 3, percent growth inhibition at one concentration: "not active" (no number reported)
For compound 3 the study gives words and no number, and the estimate cannot be compared.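

Within the data shown here, compound 3 is reported only as "not active" (no number reported), without a number, so no step from compound 2 to compound 3 can be read. The compounds shown leave open how far hydrogen in place of trifluoromethyl shifts growth inhibition. No measured evidence bears on this result.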